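The source may hold more compounds than are shown below. What is called first, only, known or untested is meant among the compounds shown, and "the series" means these compounds.

Compounds measured so far in a functional assay on MCF7 cells (Homo sapiens) for inhibition, read by MTT assay, with a stated time of 24 h; on this read-out lower numbers stand for stronger inhibition and higher numbers for weaker inhibition:

- compound 1 `O=C(O)C1=Cc2ccccc2OC1(OCc1cc(-c2ccc(F)cc2)no1)C(F)(F)F` gives 64200 nM
- compound 2 `CCOC(=O)C1=Cc2ccccc2OC1(OCc1cc(-c2ccc(OC)cc2)no1)C(F)(F)F` gives > 150000 nM
- compound 3 `CCOC(=O)C1=Cc2ccccc2OC1(OCc1cn(-c2ccc(C)cc2)nn1)C(F)(F)F` gives 26700 nM

Compound 2 stands apart from the other two in that its result is a limit of this assay and not a number: it sits at the limit of > 150000 nM in this assay, at which 1 of the 3 values shown sits. Within the data shown here, compound 1 and compound 3 each return a measured concentration; their values differ, but no step between them is counted here, so only the two values themselves are noted.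

The step to the unmeasured compound 4 `CCOC(=O)C1=Cc2ccccc2OC1(OCc1cc(-c2ccc3ccccc3c2)no1)C(F)(F)F` starts from compound 2 and changes the aryl group on the five-membered ring: naphthalen-2-yl in place of 4-methoxyphenyl on an aromatic carbon. Among the measured compounds shown here, since compound 2 gives only a limit, no measured step shows what such a change does. The expectation in this assay is that compound 4 returns a measured number rather than a limit, with a step of an at least 1.8-fold lower number from compound 2 to compound 4 (0.27 log units; that floor lies within the scatter) toward stronger inhibition, although a second limit is a real possibility. Compound 4 is estimated at 80000 nM, with a range from 20000 nM to 300000 nM.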

Compound 4, half-maximal inhibitory concentration: 65400 nM
The estimate for compound 4 lay 1.2-fold (0.09 log units) above the measured number; low and high end bracket the measured number.
By their numbers in this assay, from the lowest: compound 3; then compounds 1 and 4 (each within the scatter of the next). At a limit, above all of these: compound 2.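

In this assay, the aryl group on the five-membered ring, next to the ring nitrogen, is the only place among the compounds shown with a readable step: naphthalen-2-yl in place of 4-methoxyphenyl gives an at least 2.2-fold lower number from compound 2 to compound 4 (0.36 log units; beyond the scatter). This one change on an otherwise unchanged structure leads from a limit to a measured number. The step is a floor and not a full size, since compound 2 gives a limit and not a number: the limit of > 150000 nM in this assay, at which 1 of the 4 values shown sits.

The change adds an aromatic ring and removes the methoxy oxygen together, and the compounds shown do not separate the two. Also open, from the compounds shown here alone, is how an aryl group carrying an amine, or a saturated ring such as piperidine at the same carbon, would read.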